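A few compounds are considered here, and "the series" means these few. Any claim that something is new, unique, unknown or untested is made for them only; others in the source may bear on it.

Measured so far:
compound 1 `Cc1ccc2nc(-c3cccc(C(F)(F)F)c3)[nH]c(=O)c2c1` — 45.8%
compound 2 `Cc1ccc2c(=O)[nH]c(-c3ccccc3N(C)C)nc2c1` — 82.1%

In an assay on isolated protein for inhibition of DNA topoisomerase 1 (Homo sapiens), with a stated time of 30 min, tested at 100 uM (on this read-out higher numbers stand for a stronger effect at the one concentration tested and lower numbers for a weaker effect), compound 1 gives the lowest of the two numbers; compound 2 stands higher by a gap beyond the usual scatter. Compound 3 `Cc1ccc2nc(-c3cccc(OC(F)(F)F)c3)[nH]c(=O)c2c1` differs from compound 1 in one place: trifluoromethoxy in place of trifluoromethyl on an aromatic carbon. Among the measured compounds shown here, no measured pair shows this change, so its size is unknown; in this assay the step is expected to be small, in either direction, and most likely not beyond the scatter. Compound 3 is expected to give 45%, from 25% to 68%. The step expected is a number 0.8 percentage points lower from compound 1 to compound 3 (within the scatter).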

Compound 3, a percentage reported as inhibition, at one concentration (the size of the read-out at that concentration, not a potency): 98.6%
Compound 3: middle estimate off by 53.6 percentage points, on the low side; the whole stated range lies below it.
By their numbers in this assay, from the lowest: compound 1; then compound 2; then compound 3.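

In this assay, trifluoromethoxy in place of trifluoromethyl on an aromatic carbon, meta to a large group, gives a number 52.8 percentage points higher from compound 1 to compound 3 (beyond the scatter). Among the compounds shown here, this is the first one-place comparison, and it shows that the read-out at this position is sensitive to this exchange of groups. No available evidence bears on the cause of this step.

Still open, going by these compounds, is whether a methoxy group or a carboxylic acid at this place would keep the higher read-out. The single-concentration read-out also leaves the potency of compound 3 open.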